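Swapping the benzoyl of compound 1 for a bromophenylsulfonyl

The source may report more compounds than this note shows. Statements on the series, on what has been measured and on what is new or still open speak of the compounds shown alone.

Measured so far:
Compound 1 `CCOC(=O)Cn1ncc2c(Nc3ccc(NC(=O)c4ccccc4)cc3)ncnc21` in a functional assay on cells (Homo sapiens) for inhibition, read by MTT assay, with a stated time of 72 h (a lower number here means a stronger inhibitor, a higher number a weaker inhibitor), gives > 100 ug/mL, a limit of the assay rather than a number.
Compound 2 `CCOC(=O)Cn1ncc2c(Nc3ccc(N)cc3)ncnc21` in this assay gives > 64 ug/mL, again only a limit.
Compound 3 `O=C(O)Cn1ncc2c(Nc3ccc(NC(=O)c4ccccc4)cc3)ncnc21` in this assay gives > 100 ug/mL, also a limit.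

Compound 1 therefore stands at the upper edge of what this assay can report, and so do the two compounds that differ from it in one place. The step from it to compound 2 is a step that the two limits leave unreadable from compound 1 to compound 2, and the step to compound 3 is a step that the two limits leave unreadable from compound 1 to compound 3; both are hidden by the limits, one at the limit of > 100 ug/mL in this assay, at which 2 of the 3 values shown sit, and one at the limit of > 64 ug/mL in this assay, at which 1 of the 3 values shown sits. No readable size can be drawn from either.

The compound to be measured, compound 4 `CCOC(=O)Cn1ncc2c(Nc3ccc(NS(=O)(=O)c4ccc(Br)cc4)cc3)ncnc21`, differs from compound 1 by (4-bromophenyl)sulfonyl in place of benzoyl on a nitrogen on an aromatic ring. Neither measured step bears directly on this change, and none of the three values shows any compound leaving the limit. The expectation for compound 4 is therefore a step that the limit leaves unreadable from compound 1 to compound 4, most likely unreadable, with the assay again reporting only a limit. The estimate for compound 4 in this assay is 120 ug/mL, within a range of 40 ug/mL to 300 ug/mL.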

Compound 4, half-maximal inhibitory concentration: > 64 ug/mL
Compound 4: a limit, no number; the forecaster's own chance of this, stated with the estimate: 80%; the middle value lies beyond the limit too.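

In this assay compound 4 gives > 64 ug/mL, a limit and not a number; compound 1 and compound 2 also stand only at limits, so neither step to compound 4 can be read. The compounds shown leave open how strongly any of them inhibits, and whether benzoyl, (4-bromophenyl)sulfonyl or hydrogen on that nitrogen makes any difference.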